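Methoxy for chloro on the aryl ring of compound 3

A few compounds are considered here, and "the series" means these few. Any claim that something is new, unique, unknown or untested is made for them only; others in the source may bear on it.

Compound 3 `CN1C(=O)C(c2cccc(Cl)c2)N(C)c2nc(Nc3ccc(S(N)(=O)=O)cc3)ncc21` stands as the weakest of the three measured compounds: in an assay on Sf9 cells for inhibition of serine/threonine-protein kinase 4 (Homo sapiens), read by luminescence and ADP-Glo, with a stated time of 1 h, in the presence of a further agent that is not named here (on this read-out lower numbers stand for stronger inhibition and higher numbers for weaker inhibition), compound 3 gives 989 nM, while compound 1 `CCCC1C(=O)N(C)c2cnc(Nc3ccc(S(N)(=O)=O)cc3)nc2N1C` gives 206 nM and compound 2 `CN1C(=O)C(c2cccc(F)c2)N(C)c2nc(Nc3ccc(S(N)(=O)=O)cc3)ncc21` gives 134 nM. The step of a 4.8-fold higher number from compound 1 to compound 3 (0.68 log units; beyond the scatter) and the step of a 7.4-fold higher number from compound 2 to compound 3 (0.87 log units; beyond the scatter) both lie beyond the scatter, whereas a 1.5-fold lower number from compound 1 to compound 2 (0.19 log units; within the scatter) does not. Compound 4 `COc1cccc(C2C(=O)N(C)c3cnc(Nc4ccc(S(N)(=O)=O)cc4)nc3N2C)c1` differs from compound 3 by methoxy in place of chloro on an aromatic carbon. Going by the values given here, no measured step swaps chloro for methoxy, so the only bearing comes from the two aryl substituents already seen: fluoro gave the strongest inhibition and chloro the weakest, with a 7.4-fold higher number from compound 2 to compound 3 (0.87 log units; beyond the scatter) marking that gap. Because compound 3 sits at 989 nM and the other aryl substituent landed far lower, the author expects compound 4 to land somewhere between these outcomes, an expected step of a 2.0-fold lower number from compound 3 to compound 4 (0.30 log units; within the scatter), with wide uncertainty. Compound 4 is estimated at 500 nM, in the range 150 nM to 1800 nM.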

Compound 4, half-maximal inhibitory concentration: 954 nM
Estimate against measurement, compound 4: 1.9-fold (0.28 log units) below; measured number inside the range.
By their numbers in this assay, from the lowest: compounds 2 and 1 (each within the scatter of the next); then compounds 4 and 3 (each within the scatter of the next).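

In this assay methoxy in place of chloro on this aromatic carbon gives a 1.0-fold lower number from compound 3 to compound 4 (0.02 log units; within the scatter) and so cannot be told apart from chloro here, even though it adds a heavy atom and a hydrogen-bond acceptor. Compound 2 now stands apart from two other 3-substituted phenyl compounds rather than one, with a 7.1-fold higher number from compound 2 to compound 4 (0.85 log units; beyond the scatter) alongside its gap to compound 3, while a 4.6-fold higher number from compound 1 to compound 4 (0.67 log units; beyond the scatter) shows that 3-methoxyphenyl, like 3-chlorophenyl, gives a higher number than propyl. Nothing measured here explains these differences. From the compounds shown here alone, whether the lower number is peculiar to fluoro remains open, and a methyl, a nitrile or a trifluoromethyl on the same aromatic carbon would test that. Going by these compounds, an amine or a carboxylic acid there also remains open.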